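Amidine in place of aminocyclopropyl on a shared core

The compounds below may be only part of what the source reports. "The series", "measured", "known", "first", "only" and "open" are said of these compounds alone.

Measured compounds in an assay on isolated protein for inhibition of ubiquitin carboxyl-terminal hydrolase 7 (Homo sapiens), with stated times of 30 min and 2 h; a higher number here means a weaker inhibitor, a lower number a stronger inhibitor:
Compound 1 `Cn1nc2c(=O)n(CC3(O)CCN(Cc4ccc(-c5n[nH]c(=O)o5)cc4Cl)CC3)cnc2c1-c1ccc(CN)cc1` gives 171 nM.
Compound 2 `Cn1nc2c(=O)n(CC3(O)CCN(Cc4ccc(-c5ccco5)cc4Cl)CC3)cnc2c1-c1ccc(C2(N)CC2)cc1` gives 66.1 nM.
Compound 3 `Cn1nc2c(=O)n(CC3(O)CCN(Cc4ccc(-n5ccnc5)cc4Cl)CC3)cnc2c1-c1ccc(CN)cc1` gives 228 nM.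

Compound 2 has the lowest number of the three, and its gaps to compound 1 and to compound 3 both lie beyond the scatter. Compound 4 `Cn1nc2c(=O)n(CC3(O)CCN(Cc4ccc(-c5ccco5)cc4Cl)CC3)cnc2c1-c1ccc(C(=N)N)cc1` differs from compound 2 by a group of 3 heavy atoms (1 carbon, 2 nitrogen; no ring) in place of a group of 4 heavy atoms (3 carbon, 1 nitrogen; one three-membered non-aromatic ring of carbon only), on an aromatic carbon. Going by the values given here, the only measured step, a 1.3-fold higher number from compound 1 to compound 3 (0.12 log units; within the scatter), concerns a five-membered ring elsewhere on the molecule and stayed within the scatter, so nothing measured bears directly on this exchange. No direction can be argued from the data; a step of no more than the scatter is expected for a 1.5-fold higher number from compound 2 to compound 4 (0.18 log units; within the scatter). Compound 4 is therefore estimated at 100 nM, with an expected range from 35 nM to 300 nM.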

Compound 4, half-maximal inhibitory concentration: 87.5 nM
Compound 4: middle estimate off by 1.1-fold (0.06 log units), on the high side, within the range that was stated.
By their numbers in this assay, from the lowest: compounds 2, 4, 1 and 3 (each within the scatter of the next, the first and the last beyond it).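

In this assay, the exchange of 1-aminocyclopropyl for the amidine, on an aromatic carbon para to a large group, gives a 1.3-fold higher number from compound 2 to compound 4 (0.12 log units; within the scatter). Going by these compounds alone, this is the first step measured at this position, and it shows that the cyclopropane ring can go and an amidine can take its place with no difference beyond the scatter. No available evidence accounts for this result. The compounds shown leave open how a carboxylic acid or a 2-aminoethyl chain would read at this position on the same core.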